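The source may report more compounds than this note shows. Statements on the series, on what has been measured and on what is new or still open speak of the compounds shown alone.

Measured in a functional assay on HL-60 cells (Homo sapiens), read by calcium flux; a lower number here means that less compound is needed, a higher number that more compound is needed for the effect:

Compound 1, `Cc1cc(Cc2cccs2)c(=O)n(CC(=O)Nc2ccc(Br)cc2)n1`: compound 1 gives > 50000 nM, which is a limit of the assay and not a number.
Compound 2, `Cc1cc(Cc2ccc(C#N)cc2)c(=O)n(CC(=O)Nc2ccc(Br)cc2)n1`: compound 2 gives > 50000 nM, again a limit of the assay.

Compound 2 therefore stands at the limit of > 50000 nM in this assay, at which 2 of the 2 values shown sit, so its place among the numbers is only that it sits at the edge of what this assay can report. Among the measured compounds shown here, the one measured step, a step that the two limits leave unreadable from compound 1 to compound 2, cannot be read because both ends are limits, so no measured step tells how large a change at this part of the shared core can be. Compound 3, `COc1ccc(Nc2cc(C)nn(CC(=O)Nc3ccc(Br)cc3)c2=O)cc1`, differs from compound 2 by (4-methoxyphenyl)amino in place of 4-cyanobenzyl on an aromatic carbon. For the measured compounds named here, no measured step bears on this exchange, so the direction and size of an at least 1.6-fold lower number from compound 2 to compound 3 (0.22 log units; that floor lies within the scatter) are an open guess rather than an expectation grounded in the numbers. Given that compound 2 gives > 50000 nM, compound 3 is estimated at 30000 nM, with a range from 3000 nM to 100000 nM, and most likely the assay will again report only a limit.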

Compound 3, half-maximal effective concentration: > 50000 nM
Compound 3 ended at the assay's limit (the forecaster's own chance of this, stated with the estimate: 65%); middle value at least 1.6-fold (0.22 log units) away from the limit.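

Compound 3 gives > 50000 nM and this is a limit of the assay, not a number. Its steps from compound 1 and compound 2 cannot be read, as all three compounds sit together: the limit of > 50000 nM in this assay, at which 3 of the 3 values shown sit.

The compounds shown leave open whether any change at this part of the shared core can bring a readable number.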